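The source may hold more compounds than are shown below. What is called first, only, known or untested is meant among the compounds shown, and "the series" means these compounds.

Of the compounds shown here, three from this series have already been tested for how strongly they hold back the growth of a human lung cancer cell line. Compound 1 `CCN(CC)Cc1ccc2nc(NC(=O)N/N=C/c3cn(Cc4cccc(Cl)c4)c4ccccc34)sc2c1` gives 2410 nM in a functional assay on A549 cells (Homo sapiens) for cytotoxicity, read by MTT assay, with a stated time of 72 h; a higher number here means a weaker inhibitor, a lower number a stronger inhibitor. Compound 2 `CCN(CC)Cc1ccc2nc(NC(=O)N/N=C/c3cn(Cc4ccc(C)cc4)c4ccccc34)sc2c1` gives 1510 nM in this assay. Compound 3 `Cc1ccc(Cn2cc(/C=N/NC(=O)Nc3nc4ccc(CN(C)C)cc4s3)c3ccccc32)cc1` gives 1600 nM in this assay. All three numbers sit close together, and none of the gaps between them reaches beyond the usual scatter of repeated measurements.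

Compound 1 differs from compound 2 in one place only (3-chlorophenyl in place of 4-methylphenyl on a saturated chain carbon bound to an aromatic nitrogen), and that exchange brought a 1.6-fold higher number from compound 2 to compound 1 (0.20 log units; within the scatter). Compound 3 differs from compound 2 at another place (dimethylamino in place of diethylamino on a saturated chain carbon bound to an aromatic carbon), which brought a 1.1-fold higher number from compound 2 to compound 3 (0.03 log units; within the scatter).

Compound 4 `CN(C)Cc1ccc2nc(NC(=O)N/N=C/c3cn(Cc4cccc(Cl)c4)c4ccccc34)sc2c1` has not yet been measured. It stands to compound 3 exactly as compound 1 stands to compound 2 3-chlorophenyl in place of 4-methylphenyl on a saturated chain carbon bound to an aromatic nitrogen: the same group leaves, the same group enters, and the place is the same word for word. Going by the values given here, the only thing that sets the two pairs apart is the core they share, and that difference is the one already described between compound 2 and compound 3. Since that core change itself moved the number hardly at all, the step from compound 3 to compound 4 in this assay is expected to be about a 1.6-fold higher number from compound 3 to compound 4 (0.19 log units; within the scatter), resting on the step from compound 2 to compound 1 of a 1.6-fold higher number from compound 2 to compound 1 (0.20 log units; within the scatter). On that basis compound 4 is estimated to give 2500 nM in this assay, most likely between 1200 nM and 5200 nM.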

Compound 4, half-maximal inhibitory concentration: 1240 nM
The estimate for compound 4 lay 2.0-fold (0.30 log units) above the measured number; the range from low to high includes it.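

On the core of compound 3, putting 3-chlorophenyl in place of 4-methylphenyl gave a 1.3-fold lower number from compound 3 to compound 4 (0.11 log units; within the scatter) in this assay and this can be set beside the same change on the core of compound 2: the same change on two cores in this assay, a 1.6-fold higher number (0.20 log units; within the scatter) from compound 2 to compound 1 and a 1.3-fold lower number (0.11 log units; within the scatter) from compound 3 to compound 4, 2.1-fold (0.31 log units) apart, within the scatter of two such steps. With 3-chlorophenyl in place, dimethylamino in place of diethylamino gave a 1.9-fold lower number from compound 1 to compound 4 (0.29 log units; within the scatter) and this too can be set beside its earlier reading: the same change on two cores in this assay, a 1.1-fold higher number (0.03 log units; within the scatter) from compound 2 to compound 3 and a 1.9-fold lower number (0.29 log units; within the scatter) from compound 1 to compound 4, 2.1-fold (0.31 log units) apart, within the scatter of two such steps. So neither change gave a clearly different result on its second core, which fits with carrying them across within these four compounds, but it does not prove that either change acts the same way on both cores, and with every one of these steps inside the scatter, it does not show that either change has any real effect here.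

The compounds shown leave open whether larger steps can be reached at these two places, for example with a 4-methoxyphenyl or a pyridine ring on the saturated chain carbon bound to the aromatic nitrogen, or with a morpholine or piperazine in place of the dimethylamino and diethylamino groups. Only a step of that larger size, repeated on both cores, could test whether a change really carries from one core to the other in this series.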